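The compounds below may be only part of what the source reports. "The series", "measured", "known", "first", "only" and "open" are said of these compounds alone.

Measured so far:
- compound 1, `CCCn1c(SCc2cc([N+](=O)[O-])ccc2OC)nc2cc(NC(=O)NC(C)(C)C)ccc21`, gives 18 nM in an assay on isolated protein for inhibition of Gonadotropin-releasing hormone receptor (Homo sapiens); on this read-out higher numbers stand for weaker inhibition and lower numbers for stronger inhibition
- compound 2, `CCCCCn1c(SCc2cc([N+](=O)[O-])ccc2OC)nc2cc(NC(=O)NC(C)(C)C)ccc21`, gives 210 nM in this assay
- compound 3, `COc1ccc([N+](=O)[O-])cc1CSc1nc2cc(NC(=O)NC(C)(C)C)ccc2n1Cc1ccncc1`, gives 47 nM in this assay

Among these three, compound 1 gives the lowest number in this assay: compound 3 is its nearest neighbour, and compound 2 is the furthest. The three measured steps all alter the group on the aromatic nitrogen of the shared core: a 12-fold higher number from compound 1 to compound 2 (1.07 log units; beyond the scatter), a 2.6-fold higher number from compound 1 to compound 3 (0.42 log units; beyond the scatter) and a 4.5-fold lower number from compound 2 to compound 3 (0.65 log units; beyond the scatter).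

Compound 4, `CCCn1c(SCc2cc([N+](=O)[O-])ccc2OC)nc2cc(NC(=O)NC(C)(C)C)cc(C(=O)NCc3cccnc3)c21`, is the new compound. It differs from compound 1 at another place altogether: ((pyridin-3-yl)methyl)carbamoyl in place of hydrogen on an aromatic carbon. Going by the values given here, none of the measured steps touches this position, so they do not bear directly on the change; they only show that the number in this assay is sensitive to what is attached to the core. Among the compounds with values here, with no precedent for an addition at this aromatic carbon, a modest step in either direction is as plausible as none beyond the scatter. Compound 4 is therefore estimated at 30 nM in this assay, within a range of 8 nM to 120 nM, which means an expected step of a 1.7-fold higher number from compound 1 to compound 4 (0.22 log units; within the scatter).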

Compound 4, half-maximal inhibitory concentration: 69 nM
Estimate against measurement, compound 4: 2.3-fold (0.36 log units) below, within the range that was stated.
By their numbers in this assay, from the lowest: compound 1; then compounds 3 and 4 (each within the scatter of the next); then compound 2.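

In this assay, putting ((pyridin-3-yl)methyl)carbamoyl on the aromatic carbon ortho to a fused ring gives a 3.8-fold higher number from compound 1 to compound 4 (0.58 log units; beyond the scatter). Going by these compounds alone, this shows that a position no earlier step had touched also moves the number beyond the scatter, so the group on the aromatic nitrogen is not the only place that matters. The addition weakens inhibition without abolishing it, as compound 4 still gives 69 nM, but no measured evidence here accounts for the step.

The compounds shown leave open whether the step belongs to the carbamoyl link or to the pyridin-3-yl ring; an unsubstituted carboxamide or a carboxylic acid on this carbon would separate the two. On these data alone, it also remains open whether this addition would give a similar step on the pyridin-4-ylmethyl group of compound 3.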